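Moving a nitro group: what to expect of compound 4

The source may report more compounds than this note shows. Statements on the series, on what has been measured and on what is new or still open speak of the compounds shown alone.

In a functional assay on OVCAR-3 cells (Homo sapiens) for cytotoxicity, read by sulforhodamine B assay (on this read-out higher numbers stand for lower toxicity in this test and lower numbers for higher toxicity in this test), compound 1 `CC1=CC[C@@H]([C@@](C)(O)CCCC(C)(C)NC(=S)N/N=C\c2ccccc2)CC1` gives 43600 nM, compound 2 `CC1=CC[C@@H]([C@@](C)(O)CCCC(C)(C)NC(=S)N/N=C\c2ccc(O)cc2)CC1` gives 54400 nM and compound 3 `CC1=CC[C@@H]([C@@](C)(O)CCCC(C)(C)NC(=S)N/N=C\c2ccccc2[N+](=O)[O-])CC1` gives 41900 nM. Compound 3 therefore stands level with the other two, within the usual scatter. Compound 4 `CC1=CC[C@@H]([C@@](C)(O)CCCC(C)(C)NC(=S)N/N=C\c2cccc([N+](=O)[O-])c2)CC1` carries one change from compound 3: 3-nitrophenyl in place of 2-nitrophenyl on a carbon with a double bond to nitrogen. The measured changes on this aromatic ring bear on it: a 1.2-fold higher number from compound 1 to compound 2 (0.10 log units; within the scatter), a 1.0-fold lower number from compound 1 to compound 3 (0.02 log units; within the scatter) and a 1.3-fold lower number from compound 2 to compound 3 (0.11 log units; within the scatter). None leaves the scatter, so no real shift is expected in this assay. The estimated step is a 1.1-fold higher number from compound 3 to compound 4 (0.02 log units; within the scatter). For compound 4 the estimate is 44000 nM, with an expected range of 26000 nM to 72000 nM.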

Compound 4, concentration lethal to 50% of the cells: > 100000 nM
Compound 4: no number, only a limit (the forecaster's own chance of this, stated with the estimate: 3%); middle value at least 2.2-fold (0.35 log units) away from the limit.
By their numbers in this assay, from the lowest: compounds 3, 1 and 2 (each within the scatter of the next). At a limit, above all of these: compound 4.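

In this assay compound 4 gives no number, only a limit of the assay: the limit of > 100000 nM in this assay, at which 1 of the 4 values shown sits. So the place of the nitro group does matter here, though the earlier ring changes stayed within the scatter: 3-nitrophenyl in place of 2-nitrophenyl gives an at least 2.3-fold higher number from compound 3 to compound 4 (0.37 log units; beyond the scatter), and the comparison without any nitro group gives an at least 2.2-fold higher number from compound 1 to compound 4 (0.36 log units; beyond the scatter), both pointing to lower toxicity in this test. The comparison with the 4-hydroxyphenyl ring is less firm, at an at least 1.8-fold higher number from compound 2 to compound 4 (0.26 log units; that floor lies within the scatter). From the compounds shown here alone, how far compound 4 lies past its limit stays open. So does whether 4-nitrophenyl or 3-aminophenyl would behave like 3-nitrophenyl.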